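Solubility notes: nitrile in place of methyl on the shared core

This account rests on a few compounds, and the source may have more. Where it says the series, first, only, none or still open, it means among the compounds named here.

Of the compounds shown here, two of the shared core have been measured in a physicochemical assay for solubility; on this read-out higher numbers stand for higher solubility and lower numbers for lower solubility. Within the data shown here, compound 1 `CNC(=O)c1cc(C(=O)NC2CC2)cn(Cc2ccc(C)cc2)c1=O` gives 24 ug/mL in this assay, the only plain number among the values shown. Compound 2 `CNC(=O)c1cc(C(=O)NCCO)cn(Cc2ccccc2)c1=O` sits at a limit of this assay, >= 140 ug/mL, and no number is known for it. For compound 2 the record is the limit of >= 140 ug/mL in this assay, at which 1 of the 2 values shown sits, and nothing more.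

Compound 3 `CNC(=O)c1cc(C(=O)NC2CC2)cn(Cc2cccc(C#N)c2)c1=O` has not yet been measured in this assay. It differs from compound 1 in one place: 3-cyanophenyl in place of 4-methylphenyl on a saturated chain carbon bound to an aromatic nitrogen. Among the measured compounds shown here, no step between two measured compounds is recorded. The effect of such a change on this assay is not known from measurement, and the expectation below rests on compound 1 alone. Compound 3 is expected to give 45 ug/mL, within 18 ug/mL to 110 ug/mL. The step of a 1.9-fold higher number from compound 1 to compound 3 (0.27 log units; within the scatter) is the expected change in this assay, a modest rise that may not stand clear of the usual scatter.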

Compound 3, solubility: >= 148 ug/mL
Compound 3: only a limit was reported; the forecaster's own chance of this, stated with the estimate: 10%; middle value at least 3.2-fold (0.51 log units) away from the limit.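

In this assay, among these compounds, the change of 4-methylphenyl to 3-cyanophenyl on a saturated chain carbon bound to an aromatic nitrogen gives an at least 6.1-fold higher number from compound 1 to compound 3 (0.79 log units; beyond the scatter), the only step on record and one that lies beyond the scatter. Compound 3 stands at a limit of this assay, >= 148 ug/mL, and not at a number, so the step has a floor but no known size. The earlier compounds gave no reading of this position, and the read-out now shows that it responds to a change of this group: the limit of >= 148 ug/mL in this assay, at which 1 of the 3 values shown sits.

From the compounds shown here alone, whether the nitrile, the loss of the methyl or the new place on the ring carries the step remains open, as all three arrive in one change. An amine or a carboxylic acid in place of the nitrile would show whether the step depends on the nitrile itself.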